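Adding a Second Chloro to the Aryl Piperazine

This account rests on a few compounds, and the source may have more. Where it says the series, first, only, none or still open, it means among the compounds named here.

Compound 1 `Nc1scc(CN2CCN(c3cccc(C(F)(F)F)c3)CC2)c1C(=O)c1ccc(Cl)cc1` and compound 2 `Nc1scc(CN2CCN(c3cccc(Cl)c3)CC2)c1C(=O)c1ccc(Cl)cc1` share one core and differ only in the group on the aryl piperazine. In a functional assay on CHO cells with adenosine receptor A1 (Homo sapiens) as the target, read by cAMP accumulation and immunoassay, with a stated time of 6 min, tested at 0.01 uM (a higher number here means a weaker effect of the compound at the concentration tested, a lower number a stronger effect), compound 1 gives -8.2% and compound 2 gives -3.1%; the step of a number 5.1 percentage points higher from compound 1 to compound 2 (within the scatter) leaves compound 2 standing alongside compound 1, the two numbers within the scatter of one another. Compound 3 `Nc1scc(CN2CCN(c3ccc(Cl)c(Cl)c3)CC2)c1C(=O)c1ccc(Cl)cc1` carries chloro in place of hydrogen on an aromatic carbon. Among the measured compounds shown here, no measured step tests an added chloro; the only step, a number 5.1 percentage points higher from compound 1 to compound 2 (within the scatter), swaps one group for another and was small. The estimate for compound 3 in this assay is therefore -4%, between -16% and 8%, an expected step of a number 0.9 percentage points lower from compound 2 to compound 3 (within the scatter) not beyond the scatter.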

Compound 3, a percentage reported as activity, at one concentration (the size of the read-out at that concentration, not a potency): -1.2%
Compound 3: the middle estimate sits 2.8 percentage points below what was measured; the range from low to high includes it.
By their numbers in this assay, from the lowest: compounds 1, 2 and 3 (each within the scatter of the next).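

In this assay, a chloro on the aromatic carbon ortho to a chloro group and para to a large group gives a number 1.9 percentage points higher from compound 2 to compound 3 (within the scatter) and so adds a second chloro without a step beyond the scatter. The 3,4-dichlorophenyl group likewise stands with the 3-(trifluoromethyl)phenyl group, with a number 7 percentage points higher from compound 1 to compound 3 (within the scatter) as the step between them. No available evidence bears on this result.

As far as these compounds go, whether an amine, a methoxy group or a carboxylic acid at this carbon would read the same remains open. So does whether these compounds separate at other concentrations.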